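Hydroxyphenyl placement on a thiophene-bearing core and topoisomerase inhibition

The source may hold more compounds than are shown below. What is called first, only, known or untested is meant among the compounds shown, and "the series" means these compounds.

Measured compounds:
compound 1 `Oc1ccc(-c2cc(-c3cccs3)cc(-c3ccccc3O)n2)cc1` gives 2%
compound 2 `Oc1ccc(-c2cc(-c3cccs3)cc(-c3cccc(O)c3)n2)cc1` gives 1.1%

These values come from an assay on isolated protein for inhibition of DNA topoisomerase 1 (Homo sapiens), with a stated time of 30 min, tested at 20 uM; a higher number here means a stronger effect of the compound at the concentration tested, a lower number a weaker effect. Compound 1 and compound 2 share a core, and they differ by 3-hydroxyphenyl in place of 2-hydroxyphenyl on an aromatic carbon. That change gave a number 0.9 percentage points lower from compound 1 to compound 2 (within the scatter), so the two values say the same thing: little effect at the concentration used.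

Compound 3 `Oc1cccc(-c2cc(-c3ccsc3)cc(-c3ccccc3O)n2)c1` carries a different core; how the two cores differ is not broken down here. For compound 3 the result in this assay is "not determined" (no result reported), so nothing is known of its own level.

Compound 4 `Oc1cccc(-c2cc(-c3ccsc3)cc(-c3cccc(O)c3)n2)c1` is derived from compound 3 by the same kind of change, namely (3-hydroxyphenyl in place of 2-hydroxyphenyl on an aromatic carbon). The surroundings differ from the first case: here the changed group sits meta to a 3-hydroxyphenyl group and meta to a thiophen-3-yl group, whereas in compound 1 it sat meta to a 4-hydroxyphenyl group and a thiophen-2-yl group. With no value for compound 3, the expectation can rest only on the fact that both measured compounds sit low, and that the move from compound 1 to compound 2 stayed within the scatter. Compound 4 is therefore expected to give about 2%, estimated between -6% and 12%.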

Compound 4, a percentage reported as inhibition, at one concentration (the size of the read-out at that concentration, not a potency): 4.5%
For compound 4 the middle estimate is 2.5 percentage points below the measured one; the range from low to high includes it.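

In this assay compound 4 gives 4.5% while compound 3 has no reported result, so no new step can be read between these two compounds. No supporting evidence bears on this result. From the compounds shown here alone, whether swapping 2-hydroxyphenyl for 3-hydroxyphenyl matters on the core of compound 3 remains open.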